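Permeability notes on the amide variation series

The source may report more compounds than this note shows. Statements on the series, on what has been measured and on what is new or still open speak of the compounds shown alone.

Values in an ADME assay for permeability, using PAMPA (a higher number here means that the compound crosses the layer faster, a lower number that the compound crosses the layer more slowly), for the measured compounds:
compound 1 `C=CC(=O)Nc1cccc(-c2nc3ccccc3s2)c1`: 797 10^-6 cm/s
compound 2 `C/C=C/C(=O)Nc1cccc(-c2nc3ccccc3s2)c1`: 1640 10^-6 cm/s
compound 3 `C=C(C)C(=O)Nc1cccc(-c2nc3ccccc3s2)c1`: 987 10^-6 cm/s

Compound 3 stands second highest of the three numbers. Its nearest neighbour is compound 1, with a 1.2-fold higher number from compound 1 to compound 3 (0.09 log units; within the scatter) within the scatter; its furthest is compound 2, with a 1.7-fold lower number from compound 2 to compound 3 (0.22 log units; within the scatter) also within the scatter. For the measured compounds named here, the only step beyond the scatter among the measured pairs is a 2.1-fold higher number from compound 1 to compound 2 (0.31 log units; beyond the scatter).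

Compound 4 `O=C(Nc1cccc(-c2nc3ccccc3s2)c1)c1cccnc1Cl` is the next to be measured. The change is 2-chloropyridin-3-yl in place of 1-methylethenyl on a carbonyl carbon. Going by the values given here, none of the measured steps bears directly on this: each of them swaps only small chain carbons on the carbonyl carbon, and no measured pair brings in a ring or a hydrogen-bond acceptor. The measured steps therefore give no direction, and the expectation is a step in this assay of no more than the scatter. The step expected from compound 3 to compound 4 is a 1.3-fold lower number from compound 3 to compound 4 (0.12 log units; within the scatter). For compound 4 the estimate is 750 10^-6 cm/s, with a range from 350 10^-6 cm/s to 1500 10^-6 cm/s.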

Compound 4, apparent permeability: 677 10^-6 cm/s
Compound 4: the middle estimate sits 1.1-fold (0.04 log units) above what was measured; measured number inside the range.
By their numbers in this assay, from the lowest: compounds 4, 1, 3 and 2 (each within the scatter of the next, the first and the last beyond it).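

At this position, on a carbonyl carbon whose other neighbour is an amide-type nitrogen, the series now carries a ring with a hydrogen-bond acceptor, 2-chloropyridin-3-yl, and this assay does not separate it from the small chains: the readings are a 1.5-fold lower number from compound 3 to compound 4 (0.16 log units; within the scatter) and a 1.2-fold lower number from compound 1 to compound 4 (0.07 log units; within the scatter). Only against prop-1-en-1-yl does the difference pass the scatter, with a 2.4-fold lower number from compound 2 to compound 4 (0.38 log units; beyond the scatter), so the place tolerates an aromatic ring here without a clear loss relative to vinyl or 1-methylethenyl. Nothing at hand explains these numbers.

A plain phenyl on the same carbonyl carbon would show whether the chlorine and the ring nitrogen matter at all. On these data alone, how an amine or a carboxylic acid at this place would read remains open.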